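The compounds below may be only part of what the source reports. "The series", "measured", "known", "first", "only" and "open" are said of these compounds alone.

Compound 1 `Cc1c(O)nc(Sc2ccc(F)cc2F)nc1Cc1c(F)cccc1F` is a reference point that the numbers leave half-drawn: in a functional assay on MT4 cells (Homo sapiens) for cytotoxicity, read by MTT assay (on this read-out lower numbers stand for higher toxicity in this test and higher numbers for lower toxicity in this test), compound 1 gives > 65800 nM, which is a limit of the assay rather than a number. Its partner compound 2 `Cc1c(O)nc(Sc2ccc(Cl)cc2)nc1Cc1c(F)cccc1F` is in the same situation, since in this assay compound 2 gives > 66100 nM, again a limit. The step that the two limits leave unreadable from compound 1 to compound 2 is therefore not readable in size, as the limit of > 65800 nM in this assay, at which 1 of the 2 values shown sits, and the limit of > 66100 nM in this assay, at which 1 of the 2 values shown sits, both show. Compound 3 `Cc1c(O)nc(Sc2ccc(F)cc2F)nc1Cc1c(Cl)cccc1Cl` is the new member, and it differs from compound 1 as follows: 2,6-dichlorophenyl in place of 2,6-difluorophenyl on a saturated chain carbon bound to an aromatic carbon. Within the data shown here, no measured step touches this place, since the single measured step alters the group on the sulfur, so the expectation rests on compound 1 alone sitting at its limit. Compound 3 is expected to give 66000 nM, with a range from 25000 nM to 150000 nM. The step that the limit leaves unreadable from compound 1 to compound 3 is expected to show no change beyond the scatter.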

Compound 3, half-maximal cytotoxic concentration: > 60500 nM
Compound 3: a limit, no number; the forecaster's own chance of this, stated with the estimate: 75%; the middle value does not contradict the limit.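

In this assay, among these compounds, compound 3 gives > 60500 nM, again a limit and not a number, and no step from compound 1 to compound 3 can be read. The compounds shown leave open at what concentration compound 1, compound 2 or compound 3 would reach the half-maximal cytotoxic effect, and whether either change alters it.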